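Second Methyl on the Aryl Ring: Solubility Outlook

The compounds below may be only part of what the source reports. "The series", "measured", "known", "first", "only" and "open" are said of these compounds alone.

Compound 3, `Cc1ccc(-c2nc(CN3CCC(C(=O)NCCCN4C[C@H](C)C[C@H](C)C4)CC3)c(C)o2)cc1`, is known in a physicochemical assay for solubility, in phosphate buffer, measured as kinetic solubility, at pH 7.4 (on this read-out lower numbers stand for lower solubility and higher numbers for higher solubility), only by a limit: compound 3 gives > 69 ug/mL, which is a limit of the measurement and not a number. Compound 2, `Cc1cccc(F)c1-c1nc(CN2CCC(C(=O)NCCCN3C[C@H](C)C[C@H](C)C3)CC2)c(C)o1`, likewise reaches a limit in this assay, giving > 72 ug/mL. Compound 1, `Cc1ccccc1-c1nc(CN2CCC(C(=O)NCCCN3CCCC(CC(C)C)C3)CC2)c(C)o1`, gives a readable number in this assay, 54.9 ug/mL. The single one-place step among the measured compounds, a step that the two limits leave unreadable from compound 2 to compound 3, is unreadable because both ends sit at limits, as shown by the limit of > 69 ug/mL in this assay, at which 1 of the 3 values shown sits, and (the limit of > 72 ug/mL in this assay, at which 1 of the 3 values shown sits).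

Compound 4, `Cc1cc(C)cc(-c2nc(CN3CCC(C(=O)NCCCN4C[C@H](C)C[C@H](C)C4)CC3)c(C)o2)c1`, carries 3,5-dimethylphenyl in place of 4-methylphenyl on an aromatic carbon. Within the data shown here, no measured step bears directly on this change, so the measured set gives neither a size nor a direction for it beyond the scatter. Compound 4 is expected to give about 55 ug/mL, with a range from 25 ug/mL to 90 ug/mL. This estimate means an expected step of an at least 1.2-fold lower number from compound 3 to compound 4 (0.09 log units; that floor lies within the scatter), and a further limit rather than a number remains quite possible.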

Compound 4, solubility: > 71 ug/mL
Compound 4: no number, only a limit; the forecaster's own chance of this, stated with the estimate: 35%; middle value at least 1.2-fold (0.11 log units) away from the limit.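

In this assay compound 4 gives > 71 ug/mL, which is a limit and not a number. The steps to compound 4 from compound 2 and from compound 3 cannot be read. The compounds shown leave open whether 3,5-dimethylphenyl in place of 4-methylphenyl changes solubility at all, and in which direction.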